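Tert-butyl ester at the ring-carbon acid of compound 3

This account rests on a few compounds, and the source may have more. Where it says the series, first, only, none or still open, it means among the compounds named here.

The series shares one core with a trimethoxyphenyl group and varies the substituent on a double-bonded ring carbon. Compound 1 `COc1ccc2c(c1)OC(c1cc(OC)c(OC)c(OC)c1)C(C=O)=C2` carries formyl there and gives in a functional assay for inhibition of nuclear factor NF-kappa-B complex (Homo sapiens) (on this read-out lower numbers stand for stronger inhibition and higher numbers for weaker inhibition), a value of 13500 nM. Compound 2 `CCOCC1=Cc2ccc(OC)cc2OC1c1cc(OC)c(OC)c(OC)c1` carries ethoxymethyl and gives 21300 nM; the step of a 1.6-fold higher number from compound 1 to compound 2 (0.20 log units; within the scatter) is small. Compound 3 `COc1ccc2c(c1)OC(c1cc(OC)c(OC)c(OC)c1)C(C(=O)O)=C2` carries carboxy and in this assay gives only a limit, > 50000 nM. Compound 3 thus stands at the weak end of the measured set: an at least 3.7-fold higher number from compound 1 to compound 3 (0.56 log units; beyond the scatter) and an at least 2.3-fold higher number from compound 2 to compound 3 (0.37 log units; beyond the scatter), both resting on (the limit of > 50000 nM in this assay, at which 1 of the 3 values shown sits).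

Compound 4 `COc1ccc2c(c1)OC(c1cc(OC)c(OC)c(OC)c1)C(C(=O)OC(C)(C)C)=C2` differs from compound 3 by tert-butyl in place of hydrogen on an oxygen next to a carbonyl group. The step from formyl to carboxy and from ethoxymethyl to carboxy both weakened inhibition, so removing the free acid hydrogen by the tert-butyl group is expected to move the number back toward the range of compounds 1 and 2 rather than beyond it. The expected step is an at least 2.0-fold lower number from compound 3 to compound 4 (0.30 log units; that floor lies within the scatter). For compound 4 the estimated value is 25000 nM, expected to lie between 8000 nM and 80000 nM.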

Compound 4, half-maximal inhibitory concentration: 14100 nM
Compound 4: middle estimate off by 1.8-fold (0.25 log units), on the high side; the measured number falls inside the stated range.
By their numbers in this assay, from the lowest: compounds 1, 4 and 2 (each within the scatter of the next). At a limit, above all of these: compound 3.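

Replacing the hydrogen on the oxygen of the carboxy group of compound 3 with tert-butyl brings back a measured number in this assay (an at least 3.5-fold lower number from compound 3 to compound 4 (0.54 log units; beyond the scatter)). That step is only a floor, as compound 3 has a limit and not a number: (the limit of > 50000 nM in this assay, at which 1 of the 4 values shown sits). Tert-butoxycarbonyl on the double-bonded ring carbon stays within the scatter of both ethoxymethyl (a 1.5-fold lower number from compound 2 to compound 4 (0.18 log units; within the scatter)) and formyl (a 1.0-fold higher number from compound 1 to compound 4 (0.02 log units; within the scatter)), so among these four compounds only the free carboxy group stands apart.

A methyl ester, an amide or an amine on this carbon could show whether the free acid alone sets compound 3 apart. From the compounds shown here alone, whether any group here gives clearly stronger inhibition than compounds 1, 2 and 4 stays open.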